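Notes on M5 positive allosteric modulation: two measured, one pending

The source may hold more compounds than are shown below. What is called first, only, known or untested is meant among the compounds shown, and "the series" means these compounds.

Measured so far:
compound 1, `O=C1C(=O)N(Cc2ccc(Cl)nc2)c2ccc(OC(F)(F)F)cc21`: 80%
compound 2, `O=C1C(=O)N(Cc2ccc(Oc3ccccn3)cc2)c2ccc(OC(F)(F)F)cc21`: 46%

In a functional assay on CHO cells for positive allosteric modulation of muscarinic acetylcholine receptor M5 (Homo sapiens), read by FLIPR and calcium flux, with a stated time of 1 h (on this read-out lower numbers stand for smaller maximal responses and higher numbers for larger maximal responses), compound 1 gives 80%, the highest of the two numbers recorded. For the measured compounds named here, compound 2 gives 46%, a gap beyond the scatter, but compound 2 differs from compound 1 in more than one place, so no single-change step can be drawn between them.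

Compound 3, `O=C1C(=O)N(Cc2ccc(-c3cccnc3)nc2)c2ccc(OC(F)(F)F)cc21`, is the pending analogue. Relative to compound 1 the difference is pyridin-3-yl in place of chloro on an aromatic carbon. The only hint from the data is that compound 2, which also carries a larger aromatic substituent on its benzylic ring, sits lower at 46%; this is a loose guide at best.

A moderate downward step is expected, a number 18 percentage points lower from compound 1 to compound 3 (beyond the scatter), with a real chance it falls within the scatter. Compound 3 is estimated at 62%, within 38% to 86%.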

Compound 3, largest response reached (Emax), in percent of the reference or control that the assay uses: 53%
Compound 3: middle estimate off by 9 percentage points, on the high side, and the stated range covers the measured number.
By their numbers in this assay, from the lowest: compounds 2 and 3 (each within the scatter of the next); then compound 1.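

In this assay, the position next to the ring nitrogen now has its first single-change read: pyridin-3-yl in place of chloro on an aromatic carbon gives a number 27 percentage points lower from compound 1 to compound 3 (beyond the scatter), a modest step. The position still carries a whole extra aromatic ring with a clear response remaining, as compound 3 gives 53%, so chloro is not the only substituent compatible with a response here, though compound 1 at 80% remains higher. No available evidence explains the step.

The compounds shown leave open whether the ring itself or its nitrogen accounts for the step. A plain phenyl ring, a methoxy group or a morpholine on the same carbon would help separate these readings and show how far the trend with substituent size extends.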